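Rearranging a methyl: compound 1 to compound 4

The source may hold more compounds than are shown below. What is called first, only, known or untested is meant among the compounds shown, and "the series" means these compounds.

Compound 1 `CCc1cccc(NC(=O)CN2CCC(c3cccc[n+]3[O-])CC2)c1` was tested in a functional assay on HEK293 cells for agonist activity at D(4) dopamine receptor (Homo sapiens), read by FLIPR (on this read-out higher numbers stand for an effect only at larger amounts of compound and lower numbers for an effect already at smaller amounts), and gave 95 nM. Among the three compounds measured so far, compound 1 has the highest number. Its nearest neighbour is compound 2 `Cc1cc(C(=O)NCN2CCC(c3cccc[n+]3[O-])CC2)ccc1F`, which in this assay gives 50 nM; that gap lies within the scatter of repeated measurements, so the two cannot be told apart. Compound 3 `Cc1cccc(NC(=O)CN2CCC(c3nccs3)CC2)c1`, built on a different core, gives 1 nM in this assay, a gap from compound 1 that is well beyond the scatter.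

Compound 4 `Cc1cc(C)cc(NC(=O)CN2CCC(c3cccc[n+]3[O-])CC2)c1` has not yet been measured. It keeps the core and the amide of compound 1 and differs only at the amide-type nitrogen: 3,5-dimethylphenyl in place of 3-ethylphenyl on an amide-type nitrogen. The two compounds hold the same atoms, joined differently, with both side groups being carbon-only aromatic rings without donors, acceptors or charge.

For the measured compounds named here, no measured pair shows this exact change, so the expectation rests on compound 1 alone and on the small spread seen with compound 2. The step from compound 1 to compound 4 is expected to be a 1.5-fold lower number from compound 1 to compound 4 (0.16 log units; within the scatter), a shift most likely inside the scatter. For compound 4 the estimated value in this assay is 65 nM, with a plausible range from 15 nM to 280 nM.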

Compound 4, half-maximal effective concentration: 52 nM
The estimate for compound 4 lay 1.3-fold (0.10 log units) above the measured number; low and high end bracket the measured number.
By their numbers in this assay, from the lowest: compound 3; then compounds 2, 4 and 1 (each within the scatter of the next).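

Placing 3,5-dimethylphenyl in place of 3-ethylphenyl on the amide-type nitrogen gives the first one-place comparison in this assay, and it reads a 1.8-fold lower number from compound 1 to compound 4 (0.26 log units; within the scatter), so this swap cannot be told apart from repeat-to-repeat variation. The earlier compounds shown here could not show this, since none of them formed a pair differing in one place, whereas here the same atoms joined differently on this aromatic ring leave the read-out unresolved for this single pair. The data at hand offer no explanation for the result.

On these data alone, what stays open is whether this place tolerates only carbon-only aromatic rings, since all the groups compared here are of that kind, and a phenyl ring carrying an amine or a carboxylic acid, or a longer chain in place of the ring, could behave quite differently. As far as these compounds go, it is also open how much of the large gap to compound 3 belongs to the aromatic group on the amide-type nitrogen and how much to the core, since compound 3 differs from compound 1 and compound 4 in more than one place.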